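Swapping a Sulfonyl Link for a Carbonyl Link

The source may report more compounds than this note shows. Statements on the series, on what has been measured and on what is new or still open speak of the compounds shown alone.

Of the compounds shown here, two that share a core have been measured in a functional assay on PC-3 cells (Homo sapiens) for inhibition, read by MTT assay, with a stated time of 48 h; on this read-out higher numbers stand for weaker inhibition and lower numbers for stronger inhibition. Compound 1 `COc1cc(N(Cc2ccccc2)S(=O)(=O)c2ccc(C)cc2)cc(OC)c1OC` carries a benzyl group and a (4-methylphenyl)sulfonyl group on its nitrogen, and in this assay compound 1 gives 7810 nM. Compound 2 `COc1cc(N(Cc2nc3ccccc3[nH]2)S(=O)(=O)c2ccc(F)cc2)cc(OC)c1OC` differs in both groups on that nitrogen, and in this assay compound 2 gives 7990 nM. Within the data shown here, compound 2 holds the higher of the two numbers, yet its only neighbour, compound 1, sits within the usual scatter of such measurements, so the two results cannot be told apart; both point to weak inhibition.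

Compound 3 `COc1cc(N(Cc2nc3ccccc3[nH]2)C(=O)c2ccc(F)cc2)cc(OC)c1OC` has not been measured. It differs from compound 2 in a single place: (4-fluorophenyl)carbonyl in place of (4-fluorophenyl)sulfonyl on a nitrogen on an aromatic ring. Among the measured compounds shown here, no pair of measured compounds shows a change of this kind, so there is no measured step to lean on, and the plain expectation is a step that does not go beyond the scatter. The step is expected to come out as a 1.0-fold higher number from compound 2 to compound 3 (0.00 log units; within the scatter). Compound 3 is thus estimated to give about 8000 nM in this assay, with a likely range from 3000 nM to 25000 nM.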

Compound 3, half-maximal inhibitory concentration: 21900 nM
Estimate against measurement, compound 3: 2.7-fold (0.44 log units) below; the measured number falls inside the stated range.
By their numbers in this assay, from the lowest: compounds 1 and 2 (each within the scatter of the next); then compound 3.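

On a nitrogen on an aromatic ring, the link that holds the 4-fluorophenyl group affects the result: in this assay, putting (4-fluorophenyl)carbonyl in place of (4-fluorophenyl)sulfonyl gives a 2.7-fold higher number from compound 2 to compound 3 (0.44 log units; beyond the scatter), a modest move towards weaker inhibition. The earlier compounds shown here could not show this, as both carry a sulfonyl link, and they differ from each other in both groups on that nitrogen, so their matching numbers say nothing about the link alone. The change also alters the atoms of the link and its count of hydrogen-bond acceptors, but nothing available shows why the carbonyl link gives the higher number.

Among these compounds, with only this one step, it remains open whether the sulfonyl link would keep its advantage if the other group on that nitrogen were benzyl rather than the group shared by compound 2 and compound 3. Going by these compounds, it is also open where a plain methylene link, giving a (4-fluorophenyl)methyl group on that nitrogen, would fall relative to the sulfonyl and carbonyl links.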